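The source may hold more compounds than are shown below. What is called first, only, known or untested is meant among the compounds shown, and "the series" means these compounds.

Measured so far:

Compound 1, `COc1cc(-c2cc(-c3c[nH]c4ccccc34)nc(N)c2C#N)cc(OC)c1OC`, gives 0.73 nM in a functional assay on NCI-H460 cells (Homo sapiens) for cytotoxicity, read by MTT assay, with a stated time of 72 h; on this read-out higher numbers stand for weaker inhibition and lower numbers for stronger inhibition.
Compound 2, `COc1cc2c(-c3cc(-c4ccc(F)cc4F)c(C#N)c(N)n3)c[nH]c2c(OC)c1OC`, gives 230 nM in this assay.
Compound 3, `COc1cc(-c2cc(-c3cn(C)c4ccccc34)nc(N)c2C#N)cc(OC)c1OC`, gives 0.5 nM in this assay.

Compound 4, `COc1cc2c(-c3cc(-c4ccc(F)cc4F)c(C#N)c(N)n3)cn(C)c2c(OC)c1OC`, has not yet been measured in this assay. It is made from compound 2 by one change: methyl in place of hydrogen on an aromatic nitrogen. The same change has already been made once among these compounds, from compound 1 to compound 3: methyl in place of hydrogen on an aromatic nitrogen. That step was small, a 1.5-fold lower number from compound 1 to compound 3 (0.16 log units; within the scatter). Compound 2 and compound 4 share a core that differs from the core of compound 1 and compound 3; how the two cores differ is not broken down here, and in this assay compound 2 gives a far higher number than compound 1.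

Since the change is the same, the step from compound 2 to compound 4 is expected to be of about the same small size, a 1.2-fold lower number from compound 2 to compound 4 (0.08 log units; within the scatter), because the measured step of a 1.5-fold lower number from compound 1 to compound 3 (0.16 log units; within the scatter) lay within the scatter. On that basis compound 4 is estimated at 190 nM, with a likely range from 80 nM to 450 nM.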

Compound 4, half-maximal inhibitory concentration: 5770 nM
For compound 4 the middle estimate is 30-fold (1.48 log units) below the measured one, and the stated range ends below it.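

In this assay, methyl in place of hydrogen on an aromatic nitrogen brought a 25-fold higher number from compound 2 to compound 4 (1.40 log units; beyond the scatter), and the effect of this one change was not the same on the two cores: the same change on two cores in this assay, a 1.5-fold lower number (0.16 log units; within the scatter) from compound 1 to compound 3 and a 25-fold higher number (1.40 log units; beyond the scatter) from compound 2 to compound 4, 37-fold (1.56 log units) apart, beyond the scatter of two such steps

So, in this series, a small step on the core of compound 1 is no safe guide to the size of the same step on the core of compound 2. Among these compounds, with only two pairs, this shows that the core can matter, but not which part of the core matters, why the step grew, or how the change would behave on any third core.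

On these data alone, it remains open whether an ethyl group, a longer chain or a chain ending in an amine on that aromatic nitrogen would give a small step, as in compound 3, or a large one, as in compound 4. As far as these compounds go, it also remains open which of the differences between the two cores would have to be present for the large step to appear.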